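Swapping the aryl ether substituent in a pyrimidine antagonist

This account rests on a few compounds, and the source may have more. Where it says the series, first, only, none or still open, it means among the compounds named here.

Measured compounds:
compound 1, `Cc1cc(COc2ccccc2Cl)nc(-c2ccccn2)n1`, 316 nM
compound 2, `COc1ccccc1OCc1cc(C)nc(-c2ccccn2)n1`, 2000 nM
compound 3, `CC(=O)Nc1ccccc1OCc1cc(C)nc(-c2ccccn2)n1`, > 39800 nM

In a functional assay on cells for antagonist activity at Free fatty acid receptor 1 (Homo sapiens), read by TR-FRET and inositol phosphate accumulation, with a stated time of 2 h (a higher number here means a weaker inhibitor, a lower number a stronger inhibitor), compound 1 gives the lowest of the two numbers reported; compound 2 sits a 6.3-fold higher number from compound 1 to compound 2 (0.80 log units; beyond the scatter) away. For compound 3 the value is a limit of the assay, (the limit of > 39800 nM in this assay, at which 1 of the 3 values shown sits), so it carries no number. The steps away from compound 1 are a 6.3-fold higher number from compound 1 to compound 2 (0.80 log units; beyond the scatter) and an at least 120-fold higher number from compound 1 to compound 3 (2.10 log units; beyond the scatter), and from compound 2 to compound 3 an at least 19-fold higher number from compound 2 to compound 3 (1.29 log units; beyond the scatter), so every change of the group on that aryl ring shown here weakens the compound.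

The unmeasured compound 4, `Cc1cc(COc2cccc(F)c2)nc(-c2ccccn2)n1`, differs from compound 1 by 3-fluorophenyl in place of 2-chlorophenyl on an oxygen on a saturated carbon. Within the data shown here, no measured step touches this exact change; the two measured steps only show that replacing the chloro substituent costs potency, modestly with methoxy and heavily with acetamido. A halogen remains in compound 4, so a modest rise is expected, not a large one. Compound 4 is therefore estimated at 900 nM (range 250 nM to 3500 nM), a step of a 2.8-fold higher number from compound 1 to compound 4 (0.45 log units; beyond the scatter) expected in this assay.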

Compound 4, half-maximal inhibitory concentration: 794 nM
Beside the measured number, compound 4's estimate is 1.1-fold (0.05 log units) above it; low and high end bracket the measured number.
By their numbers in this assay, from the lowest: compound 1; then compound 4; then compound 2. At a limit, above all of these: compound 3.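

Compound 4 keeps a halogen on the aryl ring, and the result shows that this alone does not hold the potency of compound 1 in this assay: a 2.5-fold higher number from compound 1 to compound 4 (0.40 log units; beyond the scatter). The earlier compounds shown here changed only the chloro substituent, whereas this change replaces 2-chlorophenyl with 3-fluorophenyl, so the halogen and its place on the ring differ together and the step cannot be divided between them. So far, all three changes on this aryl ring raise the number relative to compound 1, but nothing shown here gives a measured reason for this step.

The compounds shown leave open whether the step follows the identity of the halogen or its place on the ring. They also leave open how an unsubstituted phenyl, or a carboxylic acid or an amine on that ring, would compare.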